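Fibroblast growth inhibition: from benzofuran to thiophene in compound 3

The compounds below may be only part of what the source reports. "The series", "measured", "known", "first", "only" and "open" are said of these compounds alone.

Measured so far:
compound 1, `Cc1ncnc2c1c(-c1cccs1)cn2[C@@H]1O[C@H](CO)[C@@H](O)[C@H]1O`: > 100000 nM
compound 2, `O=c1[nH]cnc2c1c(-c1cc3ccccc3o1)cn2[C@@H]1O[C@H](CO)[C@@H](O)[C@H]1O`: > 100000 nM

Two compounds of this series have been run in an ADME assay on MRC5 cells (Homo sapiens), read by MTT assay, with a stated time of 72 h (a higher number here means a weaker inhibitor, a lower number a stronger inhibitor), and neither gives a number. In this assay compound 1 reports only the limit > 100000 nM. In this assay compound 2 likewise reports only the limit > 100000 nM. Compound 2 therefore stands nowhere in particular on the numbers shown: it shares its position with compound 1, both sitting at the limit of > 100000 nM in this assay, at which 2 of the 2 values shown sit, and no ordering between the two can be read from that.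

Compound 3, `O=c1[nH]cnc2c1c(-c1cccs1)cn2[C@@H]1O[C@H](CO)[C@@H](O)[C@H]1O`, is the next member to be measured in this assay. The change from compound 2 is thiophen-2-yl in place of 1-benzofuran-2-yl on an aromatic carbon. Within the data shown here, no comparable step between measured compounds exists in this set, so the size of the step cannot be taken from the data. Given that compound 1, which already carries the thiophen-2-yl group, reports only the limit > 100000 nM, the step from compound 2 to compound 3 is expected to be none beyond the scatter, a step that the limit leaves unreadable from compound 2 to compound 3. In this assay compound 3 is expected to give 150000 nM, with a range from 60000 nM to 400000 nM, most likely again only as a limit.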

Compound 3, half-maximal inhibitory concentration: > 100000 nM
Compound 3: a limit, no number (the forecaster's own chance of this, stated with the estimate: 85%); the middle value is on the limit's open side.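

Compound 2 and compound 3 both report only a limit, so no step can be read from compound 2 to compound 3; all the values shown share one position: the limit of > 100000 nM in this assay, at which 3 of the 3 values shown sit.

The compounds shown leave open whether any member of the series gives an actual number in this assay, and how thiophen-2-yl and 1-benzofuran-2-yl would then compare.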